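The compounds below may be only part of what the source reports. "The series", "measured", "known", "first", "only" and "open" are said of these compounds alone.

In a functional assay on HeLa cells (Homo sapiens) for antiproliferative activity, read by MTT assay, with a stated time of 48 h (a lower number here means a stronger inhibitor, a higher number a weaker inhibitor), compound 1 (`c1ccc(-c2nn(-c3ccccc3)cc2-c2nc3ccccc3[nH]2)cc1`) gives 1550 nM as its value, and compound 2 (`Fc1ccc2[nH]c(-c3cn(-c4ccccc4)nc3-c3ccccc3)nc2c1`) gives 3610 nM as the higher, weaker of the two numbers. Compound 3 (`Clc1ccc2[nH]c(-c3cn(-c4ccccc4)nc3-c3ccccc3)nc2c1`) keeps the shared core and carries chloro in place of fluoro on an aromatic carbon. Within the data shown here, only one measured step bears on this change, namely fluoro in place of hydrogen on an aromatic carbon, which is modest and runs (a 2.3-fold higher number from compound 1 to compound 2 (0.37 log units; beyond the scatter)). Among the measured compounds shown here, no measured compound carries chloro, so that step is a weak guide, and only a small change without a firm direction is expected in this assay for this swap. The estimated shift (a 1.2-fold lower number from compound 2 to compound 3 (0.08 log units; within the scatter)) is expected to stay within the scatter. For compound 3 the estimated value is 3000 nM with an expected range of 1200 nM to 7000 nM in this read-out.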

Compound 3, half-maximal inhibitory concentration: 3480 nM
Compound 3: the middle estimate sits 1.2-fold (0.06 log units) below what was measured, and the stated range covers the measured number.
By their numbers in this assay, from the lowest: compound 1; then compounds 3 and 2 (each within the scatter of the next).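

Notes on this position: in this assay, chloro in place of fluoro on this aromatic carbon gives a 1.0-fold lower number from compound 2 to compound 3 (0.02 log units; within the scatter), so the two halogens cannot be told apart here. Set against the unsubstituted compound, chloro gives a 2.2-fold higher number from compound 1 to compound 3 (0.35 log units; beyond the scatter), and fluoro gives a 2.3-fold higher number from compound 1 to compound 2 (0.37 log units; beyond the scatter), so among these three compounds the weaker reading is not specific to fluoro but appears with either halogen. No measured evidence at hand explains this weaker reading or the match between the two halogens.

As far as these compounds go, whether a non-halogen group on this carbon, such as methoxy, an amine or a carboxylic acid, would also read weaker than compound 1 remains open. Also open, from the compounds shown here alone, is whether chloro on another aromatic carbon of the same ring would read like compound 3.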